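The source may report more compounds than this note shows. Statements on the series, on what has been measured and on what is new or still open speak of the compounds shown alone.

Measured compounds in a functional assay on A549 cells (Homo sapiens) for antiproliferative activity, read by MTT assay, with a stated time of 24 h; on this read-out lower numbers stand for stronger inhibition and higher numbers for weaker inhibition:
Compound 1 `O=C(NNC(=O)c1cccc(Cl)c1)c1ccc(NS(=O)(=O)c2cnc(O)nc2O)cc1` gives 2290 nM.
Compound 2 `O=C(NNC(=O)c1ccccc1F)c1ccc(NS(=O)(=O)c2cnc(O)nc2O)cc1` gives 7610 nM.
Compound 3 `O=C(NNC(=O)c1cccc(NS(=O)(=O)c2cnc(O)nc2O)c1)c1cccc(Cl)c1` gives 6000 nM.

Compound 1 and compound 2 share a core and differ in one place: 2-fluorophenyl in place of 3-chlorophenyl on a carbonyl carbon. That change produced a 3.3-fold higher number from compound 1 to compound 2 (0.52 log units; beyond the scatter) in this assay. Compound 3 is built from the same atoms as compound 1, joined differently; the difference between the two cores is not broken down here. Among the three, compound 3 and compound 2 lie within the scatter of each other, while compound 1 gives a lower number than compound 3 in this assay, a gap beyond the scatter.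

Compound 4 `O=C(NNC(=O)c1ccccc1F)c1cccc(NS(=O)(=O)c2cnc(O)nc2O)c1` has not yet been measured. It stands to compound 3 exactly as compound 2 stands to compound 1: 2-fluorophenyl in place of 3-chlorophenyl on a carbonyl carbon. The place is the same in both pairs, a carbonyl carbon whose other neighbour is an amide-type nitrogen, so this is the same change, now made on the core of compound 3. Among the measured compounds shown here, only one earlier instance of the change is known, and it sits on a different core, so how closely it will carry over is uncertain. The step expected in this assay is a 2.8-fold higher number from compound 3 to compound 4 (0.45 log units; beyond the scatter), set beside the measured 3.3-fold higher number from compound 1 to compound 2 (0.52 log units; beyond the scatter) and tempered somewhat for the change of core. Compound 4 is thus expected to give about 17000 nM in this assay, most likely between 7000 nM and 45000 nM.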

Compound 4, half-maximal inhibitory concentration: 10800 nM
Compound 4: middle estimate off by 1.6-fold (0.20 log units), on the high side; the measured number falls inside the stated range.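

In this assay, putting 2-fluorophenyl in place of 3-chlorophenyl on the core of compound 3 gives a 1.8-fold higher number from compound 3 to compound 4 (0.26 log units; within the scatter), so on this core the step alone cannot be told apart from the ordinary spread of repeated measurements. Among the compounds shown here, this does not establish that the change has one fixed size, nor that it would carry over to any further core, as only two cores are compared and only the step on the core of compound 1 is clearly resolved. What the comparison does show is that the two instances are compatible with a single shared step, with nothing here to indicate that the change behaves differently on the two cores: the same change on two cores in this assay, a 3.3-fold higher number (0.52 log units; beyond the scatter) from compound 1 to compound 2 and a 1.8-fold higher number (0.26 log units; within the scatter) from compound 3 to compound 4, 1.8-fold (0.27 log units) apart, within the scatter of two such steps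

The compounds shown leave open which part of the change matters, as the halogen and its ring position change together in both pairs, and a 3-fluorophenyl or a 2-chlorophenyl group on the same carbonyl carbon would separate the two. Going by these compounds, it also remains open how the two cores would respond to an unsubstituted phenyl, or to a phenyl ring carrying a methoxy group or an amine.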